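This account rests on a few compounds, and the source may have more. Where it says the series, first, only, none or still open, it means among the compounds named here.

Compound 1 `Cc1ccc(NC(=O)/C=C/c2ccccc2)c(C(N)=O)c1` gives 65.4% in a functional assay on K562 cells (Homo sapiens) for antiproliferative activity, read by trypan blue exclusion, with a stated time of 48 h, tested at 10 uM; on this read-out higher numbers stand for more inhibition of growth at the one concentration tested and lower numbers for less inhibition of growth. Compound 3 `Cc1ccc(/C=C/C(=O)Nc2ccc(Cl)cc2C(N)=O)cc1` gives 64%, within the scatter of compound 1, while compound 2 `NC(=O)c1cc(Cl)ccc1NC(=O)/C=C/c1ccccc1Br` gives 49%, beyond the scatter and lower than compound 1.

Compound 4 `NC(=O)c1cc(I)ccc1NC(=O)/C=C/c1ccccc1` has not yet been measured. It keeps the core of compound 1 and carries iodo in place of methyl on an aromatic carbon, meta to the carbamoyl group and para to a large group: iodo in place of methyl on an aromatic carbon.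

For the measured compounds named here, only one measured step is available, a number 15 percentage points higher from compound 2 to compound 3 (beyond the scatter), a modest change beyond the scatter. That step swaps 2-bromophenyl for 4-methylphenyl, not methyl for iodo, so it bears on this change only indirectly and gives no direct size for it. Going by the values given here, the data hold no measured step at this aromatic carbon, so the estimate stays close to compound 1 at 65.4%, and no change beyond the scatter is expected in this assay. The expected step is a number 4.4 percentage points lower from compound 1 to compound 4 (within the scatter), slightly downward and within the scatter. For compound 4 the estimated value is 61%, with an expected range of 47% to 74%.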

Compound 4, percent growth inhibition at one concentration: 74.5%
For compound 4 the middle estimate is 13.5 percentage points below the measured one; the measured number lies above the stated range.
By their numbers in this assay, from the lowest: compound 2; then compounds 3, 1 and 4 (each within the scatter of the next, the first and the last beyond it).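

At this aromatic carbon, meta to a carbamoyl group and para to a large group, iodo in place of methyl gives a number 9.1 percentage points higher from compound 1 to compound 4 (within the scatter) in this assay. For the compounds shown here, this is the first measured step at this position, and it shows that the two groups cannot be told apart here on this read-out, so a methyl and an iodo on the core of compound 1 both leave the growth inhibition at the same level within the scatter. The data shown offer no measurement that would explain this result.

Still open, on these data alone, is how an amine, a carboxylic acid or a methoxy group would read at this same aromatic carbon. Also open, as far as these compounds go, is whether methyl and iodo would remain level with a 2-bromophenyl or a 4-methylphenyl group on the chain, as one step on the core of compound 1 cannot show this.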